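Chloro for cyano on the core: expected rise in clearance

This account rests on a few compounds, and the source may have more. Where it says the series, first, only, none or still open, it means among the compounds named here.

Working notes on two measured members of the series and one awaiting data in an ADME assay on microsomes from liver (Rattus norvegicus) for metabolic stability, tested at 2.5 uM; on this read-out lower numbers stand for slow clearance and higher numbers for fast clearance. Compound 1 `O=S(=O)(c1ccc(F)cc1)c1cnc2cc(Cl)c(F)cc2c1-c1ccc(Cl)cc1` gives 0.57 mL/min in this assay. Compound 2 `N#Cc1ccc2c(-c3ccc(Cl)cc3)c(S(=O)(=O)c3ccc(F)cc3)cnc2c1` gives 0.01 mL/min in this assay and stands lowest of the two numbers; compound 1 is the nearest, with a higher number, a gap well beyond the scatter of the method.

Compound 3 `O=S(=O)(c1ccc(F)cc1)c1cnc2cc(Cl)ccc2c1-c1ccc(Cl)cc1` is the next member to be measured in this assay. It differs from compound 2 in one place: chloro in place of cyano on an aromatic carbon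

Within the data shown here, no step between measured compounds matches this change, so the size of the move has to be guessed. Compound 1, which also carries a chloro on its core, gives 0.57 mL/min in this assay, and that supports an expectation that compound 3 lands higher than compound 2. The expected step is estimated as a 25-fold higher number from compound 2 to compound 3 (1.40 log units; beyond the scatter), upward and beyond the scatter. Compound 3 is estimated to give 0.25 mL/min in this assay, within a range of 0.06 mL/min to 0.9 mL/min.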

Compound 3, intrinsic clearance in a liver preparation (reported as CLH), per the amount of preparation that the assay uses: 0.01 mL/min
The estimate for compound 3 lay 25-fold (1.40 log units) above the measured number; the whole stated range lies above it.
By their numbers in this assay, from the lowest: compounds 2 and 3 (each within the scatter of the next); then compound 1.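

In this assay, chloro in place of cyano on an aromatic carbon gives no change at the digits printed from compound 2 to compound 3 (within the scatter), so on this core the read-out does not separate the two groups at this position, para to a fused ring and meta to a fused ring. The chloro that compound 1 and compound 3 share therefore does not go with a high number on its own; the large move in this set comes with a different change, hydrogen in place of fluoro on an aromatic carbon, which gives a 57-fold lower number from compound 1 to compound 3 (1.76 log units; beyond the scatter), a single matched pair from which no general rule can be drawn. No measurement in hand accounts for either step, and the reason for the large move stays unknown.

Still open, from the compounds shown here alone, is whether an amine, a carboxylic acid or a longer chain on the aromatic carbon that carries the cyano of compound 2 would stay with compound 2 and compound 3 or move away from them. Also open, going by these compounds, is whether a fluoro added to the core of compound 2, with the nitrile kept, would bring the large step seen with the chloro core.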